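A few compounds are considered here, and "the series" means these few. Any claim that something is new, unique, unknown or untested is made for them only; others in the source may bear on it.

Measured compounds so far:
- compound 1 `O=Cc1cn(C[C@H]2CN(c3ccc(C4=CCS(=O)(=O)CC4)c(F)c3)C(=O)O2)nn1`, in an assay for binding affinity to Amine oxidase [flavin-containing] A (Homo sapiens); a higher number here means a weaker inhibitor, a lower number a stronger inhibitor: 3200 nM
- compound 2 `CC(C)(C)OC(=O)c1cn(C[C@H]2CN(c3ccc(C4=CCS(=O)(=O)CC4)c(F)c3)C(=O)O2)nn1`, in this assay: 3500 nM
- compound 3 `C[Si](C)(C)C#Cc1cn(C[C@H]2CN(c3ccc(C4=CCS(=O)(=O)CC4)c(F)c3)C(=O)O2)nn1`, in this assay: > 200000 nM, a limit of the assay

Compound 3 stands only as a limit; no number is known for it, and it sits at the limit of > 200000 nM in this assay, at which 1 of the 3 values shown sits. Compound 1 and compound 2 sit close together, the step of a 1.1-fold higher number from compound 1 to compound 2 (0.04 log units; within the scatter) being within the scatter. The steps into compound 3 are the large ones: an at least 62-fold higher number from compound 1 to compound 3 (1.79 log units; beyond the scatter) and an at least 57-fold higher number from compound 2 to compound 3 (1.75 log units; beyond the scatter).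

Compound 4 `CCc1cn(C[C@H]2CN(c3ccc(C4=CCS(=O)(=O)CC4)c(F)c3)C(=O)O2)nn1` is not yet measured. It differs from compound 3 by a group of 2 heavy atoms (2 carbon; no ring) in place of a group of 6 heavy atoms (5 carbon, 1 silicon; no ring), on an aromatic carbon. The two measured steps that bear on it both run into the silicon-bearing group and both were large; the step to compound 4 removes that group again, without bringing back the carbonyl that compound 1 and compound 2 carry. A return toward lower numbers is therefore expected, but of uncertain size, and a value at the limit remains possible. For compound 4 a step of an at least 4.0-fold lower number from compound 3 to compound 4 (0.60 log units; beyond the scatter) is expected, giving an estimate of 50000 nM with a range from 5000 nM to 200000 nM.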

Compound 4, inhibition constant: > 200000 nM
Compound 4 ended at the assay's limit (the forecaster's own chance of this, stated with the estimate: 40%); middle value at least 4.0-fold (0.60 log units) from the limit.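

Removing the silicon-bearing group does not bring binding back into a readable range in this assay: ethyl on this aromatic carbon also ends at the assay's limit, so that loss is not specific to silicon or the triple bond. Against the carbonyl-bearing compounds, the replacement is large in both cases, with an at least 62-fold higher number from compound 1 to compound 4 (1.79 log units; beyond the scatter) and an at least 57-fold higher number from compound 2 to compound 4 (1.75 log units; beyond the scatter) in the same assay. Within these four compounds, the two with a carbonyl on this aromatic carbon give numbers and the two without one stand at the limit: the limit of > 200000 nM in this assay, at which 2 of the 4 values shown sit.

The steps between the two limit compounds cannot be read, so the ethyl and silicon-bearing groups cannot be ordered. On these data alone, whether the carbonyl itself is required stays open, and a hydroxymethyl group, a primary amide or a carboxylic acid at this position would bear on that.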